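The source may report more compounds than this note shows. Statements on the series, on what has been measured and on what is new or still open speak of the compounds shown alone.

Measured compounds:
compound 1, `Cc1nc(S(C)(=O)=O)ccc1Oc1ncnc(OC2CCN(C(=O)OC3(C(F)(F)F)CCC3)CC2)c1F`, 82%
compound 2, `Cc1nc(S(C)(=O)=O)ccc1Oc1ncnc(OC2CCN(C(=O)SC3CCC3)CC2)c1F`, 81%
compound 3, `Cc1nc(S(C)(=O)=O)ccc1Oc1ncnc(OC2CCN(C(=O)C(C)(C)F)CC2)c1F`, 74%

In a functional assay on isolated protein for inhibition of Glucose-dependent insulinotropic receptor (Rattus norvegicus), read by HTRF and cAMP accumulation (on this read-out lower numbers stand for smaller maximal responses and higher numbers for larger maximal responses), compound 3 gives 74%, the lowest of the three numbers, though its distance to compound 2 and to compound 1 is within the scatter, so the three compounds cannot be told apart on this read-out. Compound 4, `Cc1nc(S(C)(=O)=O)ccc1Oc1ncnc(OC2CCN(C(=O)C3CCCC3)CC2)c1F`, has not yet been measured. It differs from compound 3 in one place: cyclopentyl in place of 1-fluoro-1-methylethyl on a carbonyl carbon. All three compounds already measured carry different groups on this same carbonyl carbon, and the two steps that reach compound 3 there, a number 8 percentage points lower from compound 1 to compound 3 (within the scatter) and a number 7 percentage points lower from compound 2 to compound 3 (within the scatter), both stayed within the scatter, as did a number 1 percentage points lower from compound 1 to compound 2 (within the scatter). So far, swapping groups at this position has not moved the maximal response beyond the usual noise. The same is therefore expected here: the step of a number 4 percentage points higher from compound 3 to compound 4 (within the scatter) is estimated to stay within the scatter. For compound 4 the expected value in this assay is 78%, with a range of 66% to 90%.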

Compound 4, largest response reached (reported as efficacy), in percent of the reference or control that the assay uses: 83%
For compound 4 the middle estimate is 5 percentage points below the measured one, and the stated range covers the measured number.
By their numbers in this assay, from the lowest: compounds 3, 2, 1 and 4 (each within the scatter of the next).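

In this assay, the cyclopentyl group joins the others on this carbonyl carbon without separating from them: the steps are a number 9 percentage points higher from compound 3 to compound 4 (within the scatter), a number 2 percentage points higher from compound 2 to compound 4 (within the scatter) and a number 1 percentage points higher from compound 1 to compound 4 (within the scatter). Compound 4 is new in that its group has only carbon atoms, whereas the groups of compound 1, compound 2 and compound 3 each carry fluorine, sulfur or both, so among these four compounds such atoms in this group are not needed to reach this level of maximal response. Nothing shown gives a reason why these different groups read alike.

On these data alone, whether this tolerance extends to a group carrying an amine or a carboxylic acid, or to a longer chain, remains open. Maximal response also says nothing about the concentration each compound needs to reach it.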